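Swapping a Ring Nitrogen for Carbon: Liver Stability Outlook

A few compounds are considered here, and "the series" means these few. Any claim that something is new, unique, unknown or untested is made for them only; others in the source may bear on it.

Measured compounds:
- Compound 1 `O=C(NCc1ccc(S(=O)(=O)c2ccccc2)cc1)c1nc2cnccc2[nH]1`: 73%
- Compound 2 `O=C(NCc1ccc(S(=O)(=O)N2CCCCC2)cc1)c1cc2cnccc2o1`: 46%
- Compound 3 `O=C(NCc1ccc(S(=O)(=O)N2CCCCC2)cc1)c1cc2cccnc2s1`: "below limit of detection" (no number reported)

In an ADME assay on microsomes from liver (Homo sapiens) for metabolic stability, read by LC-MS, with a stated time of 30 min, tested at 1 uM (on this read-out lower numbers stand for a less stable compound and higher numbers for a more stable compound), compound 1 gives 73%, the higher of the two numbers that were obtained, and its gap to compound 2 lies beyond the usual scatter. Compound 2 gives 46% in this assay. For compound 3 only a limit of the assay is recorded, not a number. Among the compounds with values here, no pair of these three differs in just one place, so none of them shows how a single change shifts this read-out.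

Compound 4 `O=C(NCc1ccc(S(=O)(=O)c2ccccc2)cc1)c1cc2cnccc2[nH]1` has not been measured. It differs from compound 1 in one place: a group of 9 heavy atoms (7 carbon, 2 nitrogen; one five-membered aromatic ring with 1 hetero atom, one six-membered aromatic ring with 1 hetero atom) in place of a group of 9 heavy atoms (6 carbon, 3 nitrogen; one five-membered aromatic ring with 2 hetero atoms, one six-membered aromatic ring with 1 hetero atom), on a carbonyl carbon. The rest of the molecule, including the sulfonyl-bearing side, is unchanged.

Within the data shown here, with no measured pair to lean on, the expected step from compound 1 to compound 4 is modest and pointing downward, a number 13 percentage points lower from compound 1 to compound 4 (beyond the scatter), though a change within the scatter cannot be ruled out. Compound 4 is therefore estimated to give about 60% in this assay, with a likely range from 35% to 85%.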

Compound 4, percent of the compound remaining: 75%
For compound 4 the middle estimate is 15 percentage points below the measured one; the measured number falls inside the stated range.
By their numbers in this assay, from the lowest: compound 2; then compounds 1 and 4 (each within the scatter of the next).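

In this assay, within the data shown here, the swap on the carbonyl carbon gives a number 2 percentage points higher from compound 1 to compound 4 (within the scatter), and this is the first comparison in the set in which only one place in the molecule differs. A five-membered aromatic ring with 1 hetero atom can therefore stand in for one with 2 hetero atoms at this position, on a carbonyl carbon whose other neighbour is an amide-type nitrogen, without a change in this read-out that exceeds the usual scatter of repeated measurements. Nothing available explains why the read-out holds steady across this swap.

Among these compounds, it remains open whether the same swap would behave in the same way with a different sulfonyl-bearing side, such as the one in compound 2, since that compound differs from compound 1 and compound 4 in more than one place. It is also unknown how this read-out would respond to a different kind of group on the same carbonyl carbon, such as a plain phenyl ring, or to a methyl group on the ring nitrogen that carries a hydrogen in compound 4.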